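The source may report more compounds than this note shows. Statements on the series, on what has been measured and on what is new or still open speak of the compounds shown alone.

Of the compounds shown here, two of a shared core have been measured in a functional assay on MCF7 cells (Homo sapiens) for cytotoxicity, read by MTT assay, with a stated time of 2 days, tested at 100 uM; on this read-out higher numbers stand for a weaker effect at the one concentration tested and lower numbers for a stronger effect. Compound 1, `CC(=O)c1cc(-c2ccc(F)cc2)cc2cc(-c3ccc(F)cc3)[nH]c12`, carries two 4-fluorophenyl groups, and in this assay compound 1 gives 20%. Compound 2, `CC(=O)c1cc(/C=C/c2ccccc2)cc2cc(-c3ccccc3)[nH]c12`, carries a plain phenyl in their place together with a further unsaturated side group, and in this assay compound 2 gives 34.1%, the highest of the two numbers and a gap from compound 1 that lies beyond the usual scatter. Compound 3, `CC(=O)c1cc(/C=C/c2ccccc2)cc2cc(-c3ccc(F)cc3)[nH]c12`, has not yet been measured. It differs from compound 2 at a single point: fluoro in place of hydrogen on an aromatic carbon. Within the data shown here, compound 1 and compound 2 differ in more than this one place, so their two numbers cannot isolate what one fluoro does here; they show only that the compound carrying 4-fluorophenyl groups gives the lower number. On that slim basis a small step downward, probably within the scatter, is expected from a number 4.1 percentage points lower from compound 2 to compound 3 (within the scatter). Compound 3 is accordingly expected to give 30% in this assay, within a range from 15% to 45%.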

Compound 3, a percentage reported as activity, at one concentration (the size of the read-out at that concentration, not a potency): 50.1%
The estimate for compound 3 lay 20.1 percentage points below the measured number, outside the stated range (above it).
By their numbers in this assay, from the lowest: compound 1; then compound 2; then compound 3.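

In this assay, the change from phenyl to 4-fluorophenyl can now be read on its own: fluoro in place of hydrogen on an aromatic carbon, para to a large group, gives a number 16 percentage points higher from compound 2 to compound 3 (beyond the scatter), so here the change goes with a weaker effect, the opposite of what the two earlier numbers had hinted at. A second single-place comparison, 2-phenylethenyl in place of 4-fluorophenyl on an aromatic carbon, gives a number 30.1 percentage points higher from compound 1 to compound 3 (beyond the scatter), which ties the 2-phenylethenyl group to a weaker effect in this pair as well. Nothing at hand bears on the reason for either step.

From the compounds shown here alone, whether the step belongs to fluoro alone, or would also appear with chloro, methoxy or an amine at the same place on the ring, stays open, as does whether it would hold if a longer chain stood in place of the 2-phenylethenyl group. Going by these compounds, the numbers also come from a single concentration, so they show only a stronger or weaker effect at that concentration, and how these steps would read at other concentrations remains open too.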